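This account rests on a few compounds, and the source may have more. Where it says the series, first, only, none or still open, it means among the compounds named here.

The measured compounds: compound 1 `Cc1ncn2c(Nc3cc[nH]n3)nccc12` at 57000 nM in a functional assay for inhibition, with Homo sapiens as the target (a higher number here means a weaker inhibitor, a lower number a stronger inhibitor), together with compound 2 `CCCc1ncn2c(Nc3cc[nH]n3)nccc12` and compound 3 `Cc1nc(C)n2c(O)nncc12`.

In this assay compound 1 gives 57000 nM. For compound 2 only a limit is recorded, > 48000 nM. For compound 3 likewise only a limit is recorded, > 48000 nM. The step that the limit leaves unreadable from compound 1 to compound 2 corresponds to ethyl in place of hydrogen on a saturated chain carbon bound to an aromatic carbon and cannot be sized because of the limit of > 48000 nM in this assay, at which 2 of the 3 values shown sit. The difference between the core of compound 1 and the core of compound 3 is not broken down here. Compound 4 `CCCc1nc(C)n2c(O)nncc12` carries the same change relative to compound 3, (ethyl in place of hydrogen on a saturated chain carbon bound to an aromatic carbon). Compound 3 already sits at the limit > 48000 nM. Compound 4 is therefore expected to remain at that limit, a step estimated at a step that the limit leaves unreadable from compound 3 to compound 4. The estimate for compound 4 is 60000 nM, expected between 30000 nM and 150000 nM.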

Compound 4, half-maximal inhibitory concentration: > 48000 nM
Compound 4: only a limit was reported; the forecaster's own chance of this, stated with the estimate: 85%; the middle value lies beyond the limit too.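

No new step can be read from compound 3 to compound 4, because both are recorded only as limits in this assay: the limit of > 48000 nM in this assay, at which 3 of the 4 values shown sit.

Going by these compounds, whether ethyl in place of hydrogen changes inhibition on either core remains open.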